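Chromenone thioethers against SW480: methyl on the fused ring

A few compounds are considered here, and "the series" means these few. Any claim that something is new, unique, unknown or untested is made for them only; others in the source may bear on it.

Measured compounds:
Compound 1 `Cc1nnc(SCc2cc(=O)c3ccccc3o2)s1` in a functional assay on SW480 cells (Homo sapiens) for cytotoxicity, read by MTT assay, with a stated time of 72 h (a higher number here means a weaker inhibitor, a lower number a stronger inhibitor), gives a limit of the assay, > 25000 nM.
Compound 2 `Cc1cc(C)nc(SCc2cc(=O)c3ccccc3o2)n1` in this assay gives a limit of the assay, > 25000 nM.
Compound 3 `Cc1ccc2oc(CSc3nc(C)cc(C)n3)cc(=O)c2c1` in this assay gives a limit of the assay, > 25000 nM.

Compound 1 and compound 2 share the chromenone thioether arrangement but differ in the heteroaromatic ring attached to sulfur; the difference between the two cores is not broken down here. Compound 3 is made from compound 2 by methyl in place of hydrogen on an aromatic carbon. Among the compounds with values here, the step this makes, a step that the two limits leave unreadable from compound 2 to compound 3, cannot be sized: both values are limits, and the limit of > 25000 nM in this assay, at which 3 of the 3 values shown sit, shows that every value recorded in this assay so far sits at that same limit. Within the data shown here, no compound among the three can be called stronger or weaker than another.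

Compound 4 `Cc1ccc2oc(CSc3nnc(C)s3)cc(=O)c2c1` is not yet measured. It is made from compound 1 by the same change, (methyl in place of hydrogen on an aromatic carbon), with the same surroundings around the place. Since compound 1 already sits at the limit > 25000 nM and the corresponding step from compound 2 to compound 3 left compound 3 at the limit > 25000 nM, the expectation for compound 4 is that it too will most likely be reported as a limit rather than a number. The expected step is a step that the limit leaves unreadable from compound 1 to compound 4. Compound 4 is estimated at 50000 nM, with a plausible range from 20000 nM to 200000 nM.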

Compound 4, half-maximal inhibitory concentration: > 25000 nM
Compound 4 ended at the assay's limit; the forecaster's own chance of this, stated with the estimate: 85%; the middle value is on the limit's open side.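

In this assay compound 4 gives > 25000 nM, a limit of the assay and not a number. Compound 1 also sits at a limit, so no new step can be read from compound 1 to compound 4: the limit of > 25000 nM in this assay, at which 4 of the 4 values shown sit.

The compounds shown leave open whether methyl in place of hydrogen on an aromatic carbon changes potency at all, as none gives a readable number.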